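Fluoro Replacing Hydrogen on a Shared Core

The source may hold more compounds than are shown below. What is called first, only, known or untested is meant among the compounds shown, and "the series" means these compounds.

Compound 3 `CS(=O)(=O)CCCn1c(Cn2c(=O)n(C3CC3)c3ccncc32)cc2ccccc21` was run in an ADME assay on HeLa cells (Homo sapiens) for cytotoxicity, read by ATP content, with a stated time of 3 days; a lower number here means that less compound is tolerated, a higher number that more compound is tolerated. In this assay compound 3 gives > 100000 nM, which is a limit of the assay rather than a number. Compound 1 `CS(=O)(=O)CCCn1c(Cn2c(=O)n(C3CC3)c3ccncc32)cc2cc(C(F)(F)F)ccc21` and compound 2 `CS(=O)(=O)CCCn1c(Cn2c(=O)n(C3CC3)c3ccncc32)cc2cc(Br)ccc21` share its core. In this assay compound 1 gives > 50000 nM, again a limit. In this assay compound 2 gives > 50000 nM, also a limit. All three values sit at the limit of > 100000 nM in this assay, at which 1 of the 3 values shown sits, or (the limit of > 50000 nM in this assay, at which 2 of the 3 values shown sit), so the steps a step that the two limits leave unreadable from compound 1 to compound 2, a step that the two limits leave unreadable from compound 1 to compound 3 and a step that the two limits leave unreadable from compound 2 to compound 3 cannot be sized or given a direction. Compound 4 `CS(=O)(=O)CCCn1c(Cn2c(=O)n(C3CC3)c3ccncc32)cc2cc(F)ccc21` differs from compound 3 by fluoro in place of hydrogen on an aromatic carbon. Within the data shown here, no measured step is readable, so no change beyond the scatter can be predicted. Compound 4 is expected to give about 100000 nM, between 40000 nM and 200000 nM. The expected step is a number no higher from compound 3 to compound 4 (the limit leaves the size open).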

Compound 4, half-maximal cytotoxic concentration: > 50000 nM
Compound 4 gave a limit, no number; the forecaster's own chance of this, stated with the estimate: 85%; the middle value does not contradict the limit.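

In this assay compound 4 gives > 50000 nM, which is a limit. Its steps to compound 1, compound 2 and compound 3 cannot be read. Left open is the concentration at which any of these four compounds becomes toxic to the cells, and whether swapping the group on the aromatic carbon changes it.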